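This account rests on a few compounds, and the source may have more. Where it says the series, first, only, none or still open, it means among the compounds named here.

Measured so far in a functional assay, read by spectrophotometry, with a stated time of 30 min (on this read-out higher numbers stand for weaker inhibition and lower numbers for stronger inhibition), are two compounds.

- Compound 1 `CCCC[Te]c1ccc(/C(C)=N/N)cc1` gives 5.08 ug/mL
- Compound 2 `CCCC[Te]c1ccc(C(C)NCc2ccccc2)cc1` gives 11.4 ug/mL

Compound 2 stands highest of the two (11.4 ug/mL), compound 1 gives 5.08 ug/mL, and the gap between these two numbers lies beyond the scatter. The next compound to be measured is compound 3 `C=CCNC(C)c1ccc([Te]CCCC)cc1`, which carries vinyl in place of phenyl on a saturated chain carbon bound to an amine nitrogen. Going by the values given here, no measured pair differs in one place only, so the size of this step is unknown. Among the compounds with values here, the only hint is that compound 1, which has no such phenyl, shows the lower number (5.08 ug/mL). In this assay the estimated step is small and expected toward a lower number, with nothing beyond the scatter (a 1.3-fold lower number from compound 2 to compound 3 (0.13 log units; within the scatter)). For compound 3 the expected value is 8.5 ug/mL (estimated range 3.5 ug/mL to 20 ug/mL).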

Compound 3, half-maximal inhibitory concentration: > 100 ug/mL
Compound 3: a limit, no number; the forecaster's own chance of this, stated with the estimate: 3%; middle value at least 11-fold (1.07 log units) away from the limit.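

Vinyl in place of phenyl on a saturated chain carbon bound to an amine nitrogen is the first change here that can be read as a single step, and in this assay it gives an at least 8.7-fold higher number from compound 2 to compound 3 (0.94 log units; beyond the scatter). Compound 3 gives > 100 ug/mL, which is a limit of the assay and not a number: the limit of > 100 ug/mL in this assay, at which 1 of the 3 values shown sits. This position is therefore not indifferent to the change, since in this assay the step from phenyl to vinyl weakens inhibition by more than the scatter.

The compounds shown do not tell whether the loss goes with the aromatic ring itself, with the smaller group or with the double bond. They also leave open how a cyclohexyl ring, a substituted phenyl or a longer saturated chain at this place would compare with compound 2.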